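Amide to Carbamoyl: What Compound 4 Might Show

A few compounds are considered here, and "the series" means these few. Any claim that something is new, unique, unknown or untested is made for them only; others in the source may bear on it.

Measured so far in a functional assay on NCI-H522 cells (Homo sapiens) for inhibition, read by sulforhodamine B assay, with a stated time of 48 h; on this read-out higher numbers stand for lower toxicity in this test and lower numbers for higher toxicity in this test:
Compound 1 `O=C(Nc1cccc(-n2cc(-c3ccncc3)c(-c3ccc(Cl)c(O)c3)n2)c1)Nc1cccc(C(F)(F)F)c1` gives > 32500 nM, which is a limit of the test rather than a number.
Compound 2 `COc1cc(-c2nn(-c3cccc(NC(=O)Nc4cc(C(F)(F)F)cc(C(F)(F)F)c4)c3)cc2-c2ccncc2)ccc1Cl` gives 6560 nM.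
Compound 3 `COc1cc(-c2nn(-c3cccc(NC(=O)c4cccc(C(F)(F)F)c4)c3)cc2-c2ccncc2)ccc1Cl` gives > 50000 nM, again a limit of the test.

Compound 3 therefore sits at the limit of > 50000 nM in this assay, at which 1 of the 3 values shown sits, so no number is known for it. Compound 1 sits at the limit of > 32500 nM in this assay, at which 1 of the 3 values shown sits, also only a limit. Compound 2 alone gives a measured number. Compound 4 `COc1cc(-c2nn(-c3cccc(NC(=O)Nc4ccc(Cl)c(Cl)c4)c3)cc2-c2ccncc2)ccc1Cl` differs from compound 3 in one place: (3,4-dichlorophenyl)amino in place of 3-(trifluoromethyl)phenyl on a carbonyl carbon. On the same core as compound 4, compound 2 carries a (3,5-bis(trifluoromethyl)phenyl)carbamoyl group and gives 6560 nM. Going by the values given here, no measured pair shows the exact step from compound 3 to compound 4. Compound 4 is expected to move toward higher toxicity, with an at least 3.3-fold lower number from compound 3 to compound 4 (0.52 log units; beyond the scatter) as the estimated step. The estimate for compound 4 is 15000 nM, expected to fall between 4000 nM and 50000 nM.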

Compound 4, concentration lethal to 50% of the cells: > 50000 nM
Compound 4 gave a limit, no number (the forecaster's own chance of this, stated with the estimate: 40%); middle value at least 3.3-fold (0.52 log units) away from the limit.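

Going by these compounds alone, compound 3 and compound 4 both give only a limit of the test, so no step between them can be read. The compounds shown leave open how far (3,4-dichlorophenyl)amino in place of 3-(trifluoromethyl)phenyl changes toxicity, if at all.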